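The compounds below may be only part of what the source reports. "The series", "measured", "known", "first", "only" and "open" are said of these compounds alone.

Compound 1 `COc1ccc(-c2c(Br)c(=O)c3c(OC)cc(OC)cc3n2S(=O)(=O)c2ccc(OC)cc2)cc1` gives 49700 nM in an ADME assay on BJ cells (Homo sapiens) for antiproliferative activity, with a stated time of 72 h; on this read-out lower numbers stand for an effect already at smaller amounts and higher numbers for an effect only at larger amounts of compound. Compound 2 `COc1ccc(-c2c(I)c(=O)c3c(OC)cc(OC)cc3n2S(=O)(=O)c2ccc(OC)cc2)cc1` gives only a limit of this assay, > 34400 nM. Compound 3 `COc1ccc(-c2cc(=O)c3c(OC)cc(OC)cc3n2S(=O)(=O)c2cccc([N+](=O)[O-])c2)cc1` likewise gives only a limit, > 39600 nM.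

All three values lie in the same weak region of this assay, and compound 3 stands at one of the two limits, with no number of its own. Compound 4 `COc1ccc(-c2cc(=O)c3c(OC)cc(OC)cc3n2S(=O)(=O)c2ccc(C)cc2)cc1` differs from compound 3 by 4-methylphenyl in place of 3-nitrophenyl on a sulfonyl sulfur. Within the data shown here, the single measured step, a step that the limit leaves unreadable from compound 1 to compound 2, concerns the halogen on the core and is unreadable because of the limit of > 34400 nM in this assay, at which 1 of the 3 values shown sits; no measured step touches the group on the sulfonyl sulfur. No shift beyond the scatter is therefore expected, and a step that the limit leaves unreadable from compound 3 to compound 4 is the estimated step. Compound 4 is expected to give 45000 nM, between 20000 nM and 100000 nM, with a fair chance that only a limit is reported.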

Compound 4, half-maximal effective concentration: > 44800 nM
Compound 4 gave a limit, no number (the forecaster's own chance of this, stated with the estimate: 55%); the middle value lies beyond the limit too.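

Compound 3 and compound 4 both give only limits, so no step can be read between them. The compounds shown leave open whether 4-methylphenyl in place of 3-nitrophenyl on a sulfonyl sulfur changes the read-out in this assay at all.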